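The compounds below may be only part of what the source reports. "The series", "measured", "known", "first", "only" and "open" are said of these compounds alone.

Working notes on the series. Compound 1, `C#CCCOC(=O)/C=C/c1ccc(OC(C)=O)c(OC(C)=O)c1`, gives 1800 nM in an assay for inhibition of Polyunsaturated fatty acid 5-lipoxygenase (Homo sapiens), read by HPLC, with a stated time of 10 min; a higher number here means a weaker inhibitor, a lower number a stronger inhibitor. Compound 2, `C#CCCCCCCCCOC(=O)/C=C/c1ccc(OC(C)=O)c(OC(C)=O)c1`, gives 180 nM in this assay. Within the data shown here, of the two numbers in hand, compound 1 is the higher, with compound 2 the only neighbour; the step of a 10-fold lower number from compound 1 to compound 2 (1.00 log units; beyond the scatter) is the single measured change, and it alters only the chain carried on the ester oxygen.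

Compound 3, `C#CCCNC(=O)/C=C/c1ccc(OC(C)=O)c(OC(C)=O)c1`, is still unmeasured. Against compound 1 the difference is a group of 5 heavy atoms (4 carbon, 1 nitrogen; no ring) in place of a group of 5 heavy atoms (4 carbon, 1 oxygen; no ring), on a carbonyl carbon, with the place being a carbonyl carbon whose other neighbour is a double-bonded chain carbon. Among the measured compounds shown here, no measured step touches this position: the step from compound 1 to compound 2 changes the chain length on the oxygen side and leaves the ester linkage itself intact, so it gives no direct guide to swapping the ester oxygen for a nitrogen bearing a hydrogen. With nothing in the data to point either way, the expected step of no change at the digits printed from compound 1 to compound 3 (within the scatter) is taken as lying within the usual scatter, and the working estimate for compound 3 in this assay is 1800 nM, expected within 600 nM to 5500 nM.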

Compound 3, half-maximal inhibitory concentration: 8230 nM
Compound 3: middle estimate off by 4.6-fold (0.66 log units), on the low side; the whole stated range lies below it.
By their numbers in this assay, from the lowest: compound 2; then compound 1; then compound 3.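

The place on the carbonyl carbon is sensitive to the atom that links the chain, which the change in chain length on the ester oxygen could not show: replacing (but-3-yn-1-yl)oxy with the nitrogen-linked group gives a 4.6-fold higher number from compound 1 to compound 3 (0.66 log units; beyond the scatter) in this assay and moves the number in the opposite direction to the step of a 10-fold lower number from compound 1 to compound 2 (1.00 log units; beyond the scatter) on the same side of the carbonyl carbon. The change is not one of size by count, since both groups hold 5 heavy atoms and no ring, and what differs is the linking atom, with 1 hydrogen-bond donor and 0 hydrogen-bond acceptors in the entering group against 0 donors and 1 acceptor in the leaving one. No measurement in hand bears on why the number rises, so this change stays an observation without an explanation.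

As far as these compounds go, whether the longer chain of compound 2 keeps its step when carried on the amide nitrogen remains open. Also open, from the compounds shown here alone, is how a thioester, a ketone or a carboxylic acid at this place would compare with the ester of compound 1 and the amide of compound 3.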